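Swapping a Pyrazole for an Acetylazetidine: Microsomal Half-Life

The source may report more compounds than this note shows. Statements on the series, on what has been measured and on what is new or still open speak of the compounds shown alone.

Of the compounds shown here, two sharing one core have so far been tested in an ADME assay on microsomes from liver (Mus musculus, strain CD-1) for metabolic stability, read by LC-MS, tested at 2 uM; on this read-out higher numbers stand for a longer-lived compound and lower numbers for a shorter-lived compound. Compound 1 `CN1CCC(NS(=O)(=O)c2ccccc2Nc2cc(-c3ccc4ccn(C)c4c3)c3nccnc3c2)C1` gives 0.667 h in this assay. Compound 2 `Cn1cc(CNC(=O)c2ccncc2Nc2cc(-c3ccc4ccn(C)c4c3)c3nccnc3c2)cn1` gives 0.267 h in this assay, the lower of the two numbers, and its gap to compound 1 lies beyond the usual scatter of repeated measurements. The two compounds differ in more than one place, so no single structural change can be tied to that gap.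

Compound 3 `CC(=O)N1CC(CNC(=O)c2ccncc2Nc2cc(-c3ccc4ccn(C)c4c3)c3nccnc3c2)C1` has not yet been measured. It differs from compound 2 in one place: 1-acetylazetidin-3-yl in place of 1-methyl-1H-pyrazol-4-yl on a saturated chain carbon bound to an amide-type nitrogen. Within the data shown here, no pair of measured compounds shows this change, so the measured numbers give no guide to how large its effect should be. On that basis the expected step is small, a 1.3-fold higher number from compound 2 to compound 3 (0.12 log units; within the scatter), with a slight lean toward a longer-lived compound but not clearly beyond the scatter. Compound 3 is therefore estimated to give 0.35 h in this assay, with a likely range from 0.15 h to 0.8 h.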

Compound 3, half-life: > 1 h
Compound 3 gave a limit, no number; the forecaster's own chance of this, stated with the estimate: 5%; middle value at least 2.8-fold (0.45 log units) from the limit.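

Putting 1-acetylazetidin-3-yl in place of 1-methyl-1H-pyrazol-4-yl on a saturated chain carbon bound to an amide-type nitrogen gives, in this assay, an at least 3.7-fold higher number from compound 2 to compound 3 (0.57 log units; beyond the scatter). Among these compounds, this is the first change in the set that sits in one place only, and it shows that the group at this position matters: swapping it alone moves the half-life beyond the usual scatter, something the earlier pair, differing in more than one place, could not show. Compound 3 gives > 1 h, which is a limit of the assay and not a number, so the step has a known floor but no known top: the limit of > 1 h in this assay, at which 1 of the 3 values shown sits.

The change replaces a five-membered aromatic ring with a four-membered non-aromatic ring and also brings in an acetyl group, and the compounds shown cannot separate these two parts of the swap. A plain 1-methylazetidin-3-yl, which keeps the four-membered ring without the acetyl, or an open-chain acetamide, which keeps the acetyl without the ring, would be needed to tell which part goes with the longer half-life.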